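Extending the amide-type nitrogen substituent of compound 3

The compounds below may be only part of what the source reports. "The series", "measured", "known", "first", "only" and "open" are said of these compounds alone.

Compound 1 `COc1cc(NC(C)CCCNC(=O)/C(C)=C/c2ccccc2)c2ncccc2c1`: in an ADME assay on L6 cells (Rattus norvegicus) for cytotoxicity, read by resazurin assay, with a stated time of 70 h (on this read-out higher numbers stand for weaker inhibition and lower numbers for stronger inhibition), compound 1 reaches only the assay limit > 100 ug/mL (the limit of > 100 ug/mL in this assay, at which 1 of the 3 values shown sits).
Compound 2 `COc1cc(NC(C)CCCNC(=O)/C=C/c2ccccc2F)c2ncccc2c1`: in this assay compound 2 gives 1.5 ug/mL.
Compound 3 `COc1cc(NC(C)CCCNC(=O)Nc2cccc(Cl)c2)c2ncccc2c1`: in this assay compound 3 gives 10 ug/mL.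

Compound 3 holds the highest of the two numerical values; the nearest comparison is the step of a 6.7-fold higher number from compound 2 to compound 3 (0.82 log units; beyond the scatter). Compound 4 `COc1cc(NC(C)CCCNC(=O)NNC(=O)Nc2cccc(Br)c2)c2ncccc2c1` differs from compound 3 by ((3-bromophenyl)carbamoyl)amino in place of 3-chlorophenyl on an amide-type nitrogen. Among the measured compounds shown here, the measured steps of an at least 10-fold lower number from compound 1 to compound 3 (1.00 log units; beyond the scatter) and a 6.7-fold higher number from compound 2 to compound 3 (0.82 log units; beyond the scatter) alter the group on the carbonyl carbon, not the substituent on the amide-type nitrogen, so no measured step covers this change directly. The step is expected to be modest and upward in this assay, a 3.0-fold higher number from compound 3 to compound 4 (0.48 log units; beyond the scatter). Compound 4 is estimated at 30 ug/mL, within 8 ug/mL to 100 ug/mL.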

Compound 4, half-maximal inhibitory concentration: 20 ug/mL
The estimate for compound 4 lay 1.5-fold (0.18 log units) above the measured number; low and high end bracket the measured number.
By their numbers in this assay, from the lowest: compound 2; then compounds 3 and 4 (each within the scatter of the next). At a limit, above all of these: compound 1.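

In this assay, placing ((3-bromophenyl)carbamoyl)amino in place of 3-chlorophenyl on the amide-type nitrogen gives a 2.0-fold higher number from compound 3 to compound 4 (0.30 log units; within the scatter), so compounds 3 and 4 cannot be told apart on this read-out. This position therefore accepts the larger group, with its 2 hydrogen-bond donors, without a step beyond the scatter. Nothing shown gives a cause for this step.

Going by these compounds, the swap changes the halogen and the link together, so the contribution of each remains open. Also open, on these data alone, is how a carboxylic acid or an amine on the phenyl ring would read in this assay.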